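Shortening the Ether Chain of Compound 1

The compounds below may be only part of what the source reports. "The series", "measured", "known", "first", "only" and "open" are said of these compounds alone.

Among the measured compounds shown here, compound 1 `CC(C)COc1ccc(NC(=O)CCCCCCCSc2nnc(Cc3nn(C)c(=O)c4ccccc34)n2C)cc1` gives 4800 nM in an assay on isolated protein (Mus musculus) for inhibition of IL15-IL15 receptor (Homo sapiens), read by resazurin assay, with stated times of 30 min and 2.5 days (a lower number here means a stronger inhibitor, a higher number a weaker inhibitor), the lower of the two numbers measured so far. Compound 2 `Cn1c(Cc2nn(C)c(=O)c3ccccc23)nnc1SCCCC(=O)Nc1ccc(Cl)cc1Cl` gives 9800 nM in this assay, a weaker result that lies beyond the usual scatter. Compound 3 `CCCOc1ccc(NC(=O)CCCCCCCSc2nnc(Cc3nn(C)c(=O)c4ccccc34)n2C)cc1` differs from compound 1 by hydrogen in place of methyl on a saturated chain carbon bound to two saturated chain carbons. For the measured compounds named here, no measured pair covers such a change, so the expectation rests on compound 1 alone. The move is expected to give a 1.3-fold higher number from compound 1 to compound 3 (0.10 log units; within the scatter), a step not clearly beyond the scatter. Compound 3 is therefore estimated at 6000 nM, within a range from 2500 nM to 15000 nM.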

Compound 3, half-maximal inhibitory concentration: 1600 nM
Estimate against measurement, compound 3: 3.8-fold (0.57 log units) above; measured number outside the range, below it.
By their numbers in this assay, from the lowest: compound 3; then compound 1; then compound 2.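

Going from isobutoxy to propoxy gives a 3.0-fold lower number from compound 1 to compound 3 (0.48 log units; beyond the scatter) in this assay, so this position responds to the loss of a single methyl, and the isobutoxy group is not required for the inhibition seen with compound 1. Among the compounds shown here, this is the first single-place comparison, since compound 1 and compound 2 differ in more than one place. Nothing available explains the change.

On these data alone, whether ethoxy or methoxy would continue in the same direction remains open. So does the effect of an amine at the end of the ether chain.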